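Methyl to hydroxy on the core of compound 1

A few compounds are considered here, and "the series" means these few. Any claim that something is new, unique, unknown or untested is made for them only; others in the source may bear on it.

Compound 1 `Cc1cc(C)c2c(C#N)cn(-c3ccc(C(C)C)cc3Br)c2n1` is the weaker of the two measured compounds in an assay on isolated protein for binding affinity to corticotropin-releasing factor receptor 1 (Rattus norvegicus); on this read-out higher numbers stand for weaker inhibition and lower numbers for stronger inhibition: compound 1 gives 363 nM, the highest of the two numbers, and its nearest neighbour is compound 2 `Cc1cc(C)c2ccn(-c3ccc(C(C)C)cc3Br)c2n1`, which in this assay gives 47 nM. For the measured compounds named here, the one measured step, a 7.7-fold lower number from compound 1 to compound 2 (0.89 log units; beyond the scatter), is a change at a different place, hydrogen in place of cyano on an aromatic carbon, and it leaves the methyl group untouched.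

Compound 3 `Cc1cc(O)nc2c1c(C#N)cn2-c1ccc(C(C)C)cc1Br` differs from compound 1 by hydroxy in place of methyl on an aromatic carbon. Going by the values given here, no measured step touches this position, so nothing among the two measured compounds shows what the exchange of methyl for hydroxy does in this assay; the direction and size of the step rest on the structural change alone. Because compound 1 already stands at 363 nM, the change is expected to move compound 3 further toward weaker binding, by a 5.5-fold higher number from compound 1 to compound 3 (0.74 log units; beyond the scatter). Among the compounds with values here, the estimate for compound 3 in this assay is therefore 2000 nM, with a range from 500 nM to 10000 nM, the range kept wide as no measured step bears directly on it.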

Compound 3, inhibition constant: > 10000 nM
Compound 3: a limit, no number; the forecaster's own chance of this, stated with the estimate: 15%; middle value at least 5.0-fold (0.69 log units) from the limit.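

For the compounds shown here, the exchange of methyl for hydroxy on the aromatic carbon next to the ring nitrogen gives the first measured step at this position, and in this assay it is an at least 27-fold higher number from compound 1 to compound 3 (1.44 log units; beyond the scatter). Going by these compounds alone, until now the only measured step lay at the cyano group, a 7.7-fold lower number from compound 1 to compound 2 (0.89 log units; beyond the scatter), so the earlier compounds could not show that this methyl position also affects the read-out, or that a single exchange of one heavy atom there can weaken binding this sharply. Compound 3 gives > 10000 nM, which is a limit of the assay and not a number, so the step fixes a minimum size and leaves the full size unknown: the limit of > 10000 nM in this assay, at which 1 of the 3 values shown sits.

The compounds shown leave open whether this loss is specific to hydroxy or follows any replacement of the methyl group at this place, a question that an amine, a methoxy group or a longer chain such as ethyl at the same carbon would address. Also open, on these data alone, is whether the same exchange would cost as much on compound 2, which carries hydrogen in place of cyano.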